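The compounds below may be only part of what the source reports. "The series", "measured", "known", "first", "only" and "open" are said of these compounds alone.

For the measured compounds named here, compound 2 `c1ccc(-c2cn3ccnc3c(-c3ccc4ncn(C5CCCCC5)c4c3)n2)cc1` stands highest of the two numbers so far in a functional assay on PC-3 cells (Homo sapiens) for inhibition, read by sulforhodamine B assay, with a stated time of 48 h, tested at 10 uM (on this read-out higher numbers stand for more inhibition at the one concentration tested (going by the name of the read-out) and lower numbers for less inhibition), where compound 2 gives 92%. Compound 1 `Brc1cn2ccnc2c(-c2ccc3ncn(C4CCCCC4)c3c2)n1`, which carries bromo where compound 2 carries phenyl, sits far lower: in this assay compound 1 gives 17.2%. That single measured step, a number 74.8 percentage points higher from compound 1 to compound 2 (beyond the scatter), is the only one on record, and it concerns a change at a different spot.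

Compound 3 `COc1ccc(-c2cn3ccnc3c(-c3ccc4ncn(C5CCCCC5)c4c3)n2)cc1` differs from compound 2 by methoxy in place of hydrogen on an aromatic carbon; cut one bond further out, the change reads phenyl to 4-methoxyphenyl, with the new group para to a large group. Going by the values given here, no measured step speaks to a methoxy at this place, so the expectation rests on compound 2 alone, whose reading of 92% already lies near the top of the scale. A change within the scatter is expected, a number 4 percentage points lower from compound 2 to compound 3 (within the scatter). Compound 3 is therefore estimated at 88%, with a range from 65% to 98%.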

Compound 3, a percentage reported as inhibition, at one concentration (the size of the read-out at that concentration, not a potency): 95.2%
Compound 3: middle estimate off by 7.2 percentage points, on the low side; the range from low to high includes it.
By their numbers in this assay, from the lowest: compound 1; then compounds 2 and 3 (each within the scatter of the next).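

In this assay, methoxy in place of hydrogen on the phenyl ring, para to a large group, gives a number 3.2 percentage points higher from compound 2 to compound 3 (within the scatter), so this position accepts a small added group with no difference that can be told from the usual scatter. Measured against the bromo compound, the aromatic ring with methoxy on it also holds a large gain, a number 78 percentage points higher from compound 1 to compound 3 (beyond the scatter), so the step away from bromo is now seen with two aromatic groups, not one. No measurement at hand bears on the reason for either step.

Going by these compounds, whether an amine, a carboxylic acid or a longer chain such as butoxy at this place would keep the reading this high remains open. On these data alone, with both readings near the top of the scale at one concentration, it is also open whether compound 2 and compound 3 would separate at lower concentrations.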